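The source may report more compounds than this note shows. Statements on the series, on what has been measured and on what is new or still open speak of the compounds shown alone.

Measured compounds:
compound 1 `O=c1[nH]c(=O)n([C@H]2C[C@H](O)[C@@H](CO)O2)cc1-c1cn(-c2ccccc2)nn1` gives 270000 nM in an ADME assay on HEL cells (Homo sapiens) for cytotoxicity, read by cell counting, with a stated time of 3 days; on this read-out lower numbers stand for higher toxicity in this test and higher numbers for lower toxicity in this test
compound 2 `CCCCc1ccc(-n2cc(-c3cn([C@H]4C[C@H](O)[C@@H](CO)O4)c(=O)[nH]c3=O)nn2)cc1` gives 230000 nM in this assay

Going by the values given here, compound 2 gives the lowest of the two numbers so far in this assay, with compound 1 showing a 1.2-fold lower number from compound 1 to compound 2 (0.07 log units; within the scatter), so the two cannot be told apart. Compound 3 `O=c1[nH]c(=O)n([C@H]2C[C@H](O)[C@@H](CO)O2)cc1-c1cn(-c2ccc(Cl)cc2)nn1` has not yet been tested in this assay; it differs from compound 2 by chloro in place of butyl on an aromatic carbon, on an aromatic carbon of a six-membered aromatic ring of carbon only. Among the compounds with values here, no measured step swaps groups at that carbon; the only step there, from compound 1 to compound 2, stayed within the scatter. Compound 3 is therefore expected to show a 1.1-fold higher number from compound 2 to compound 3 (0.04 log units; within the scatter), landing near 250000 nM with a range of 120000 nM to 500000 nM.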

Compound 3, minimum cytotoxic concentration: > 240000 nM
Compound 3: only a limit was reported; the forecaster's own chance of this, stated with the estimate: 30%; the middle value lies beyond the limit too.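

In this assay, compound 3 gives only a limit of the assay, not a number: the limit of > 240000 nM in this assay, at which 1 of the 3 values shown sits.
Chloro in place of butyl on this aromatic carbon gives an at least 1.0-fold higher number from compound 2 to compound 3 (0.01 log units; that floor lies within the scatter), so this first exchange of one substituent for another at that carbon brings no lower number. The step from compound 1 to compound 3 cannot be read. On these data alone, it remains open whether an amine, a carboxylic acid or a longer chain at this carbon would bring the number down. As far as these compounds go, the true value of compound 3 also remains unknown.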